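Swapping fluoro for methyl on a peroxide-bearing quinoline amine

The source may report more compounds than this note shows. Statements on the series, on what has been measured and on what is new or still open speak of the compounds shown alone.

Compound 3 `COc1cc(NC(C)CCCNCC2CCC3(CC2)OOC2(OO3)C3CC4CC(C3)CC2C4)c2ncccc2c1-c1ccc(F)cc1` carries the shared core of compound 1 `COc1cc(NC(C)CCCNC(=O)C2CCC3(CC2)OOC2(OO3)C3CC4CC(C3)CC2C4)c2ncccc2c1-c1ccc(F)cc1` with a methylene link in place of the amide. In an ADME assay on Caco-2 cells (Homo sapiens) for cytotoxicity, read by neutral red uptake, with a stated time of 72 h (on this read-out higher numbers stand for lower toxicity in this test and lower numbers for higher toxicity in this test), compound 3 gives "not determined" (no result reported), so no number places it on this read-out. Compound 2 `COc1cc(NCCCNC(=O)C2CCC3(CC2)OOC2(OO3)C3CC4CC(C3)CC2C4)c2ncccc2c1-c1ccc(F)cc1` likewise gives "not determined" (no result reported) in this assay. Among the measured compounds shown here, compound 1 is the only member of the set with an entry, and that entry is a limit of the assay rather than a number: in this assay compound 1 reaches > 50000 nM. The single fixed point is therefore (the limit of > 50000 nM in this assay, at which 1 of the 3 values shown sits), and nothing about the removal of the amide carbonyl or the added methyl on the linker can be read from these entries.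

Compound 4 `COc1cc(NC(C)CCCNCC2CCC3(CC2)OOC2(OO3)C3CC4CC(C3)CC2C4)c2ncccc2c1-c1ccc(C)cc1` differs from compound 3 by methyl in place of fluoro on an aromatic carbon. For the measured compounds named here, with no measured step anywhere in the set, the change is expected to move this assay by no more than the usual scatter, in no particular direction. Compound 4 is accordingly expected to return about 60000 nM in this assay, within a range from 20000 nM to 200000 nM, most probably again as a limit.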

Compound 4, half-maximal cytotoxic concentration: 11700 nM
For compound 4 the middle estimate is 5.1-fold (0.71 log units) above the measured one, and the stated range ends above it.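

In this assay, among the compounds shown here, compound 4 gives 11700 nM, but compound 3 has no number to set against it, so no step between compound 3 and compound 4 can be read. Going by these compounds, what the change from 4-fluorophenyl to 4-methylphenyl does to this read-out stays open. Compound 1 holds the only other entry, which is a limit: the limit of > 50000 nM in this assay, at which 1 of the 4 values shown sits.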